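A few compounds are considered here, and "the series" means these few. Any claim that something is new, unique, unknown or untested is made for them only; others in the source may bear on it.

Of the compounds shown here, three have been measured in a functional assay on GBM2 cells (Homo sapiens) for antiproliferative activity, read by WST assay, with a stated time of 72 h; a higher number here means a weaker inhibitor, a lower number a stronger inhibitor. Compound 1 (`O=C(Nc1ccc(C(F)(F)F)cc1)Nc1cc2ncncc2cc1OCc1cccc(F)c1`) gives 3200 nM, compound 2 (`O=C(Nc1cc2ncncc2cc1OCc1ccc(Cl)cc1)Nc1cccc2ccccc12`) gives 4500 nM, and compound 3 (`O=C(Nc1ccc(Cl)c(Cl)c1)Nc1cc2ncncc2cc1OCc1cccc(F)c1`) gives 1500 nM, the lowest number of the three. Compound 4 (`O=C(Nc1cc2ncncc2cc1OCc1cccc(F)c1)Nc1cccc2ccccc12`) departs from compound 3 by a single change: naphthalen-1-yl in place of 3,4-dichlorophenyl on an amide-type nitrogen.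

Among the compounds with values here, no measured step covers this exact exchange. Within the data shown here, the only measured step at this place is a 2.1-fold lower number from compound 1 to compound 3 (0.33 log units; beyond the scatter), a modest one that involves a different pair of groups, so it suggests a size but not a direction. Direction comes from compound 2, which carries naphthalen-1-yl on the same nitrogen and gives 4500 nM, although it also differs from compound 4 elsewhere in the structure. The evidence therefore points to a modest loss of activity in this assay. The estimate means a 2.0-fold higher number from compound 3 to compound 4 (0.30 log units; within the scatter), an expected step of about that modest size. Compound 4 is estimated at 3000 nM, with an expected range from 1300 nM to 6500 nM.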

Compound 4, half-maximal inhibitory concentration: 1400 nM
Beside the measured number, compound 4's estimate is 2.1-fold (0.33 log units) above it; measured number inside the range.
By their numbers in this assay, from the lowest: compounds 4 and 3 (each within the scatter of the next); then compounds 1 and 2 (each within the scatter of the next).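

In this assay, naphthalen-1-yl in place of 3,4-dichlorophenyl on the amide-type nitrogen gives a 1.1-fold lower number from compound 3 to compound 4 (0.03 log units; within the scatter), so the two groups cannot be told apart at this position, while naphthalen-1-yl in place of 4-(trifluoromethyl)phenyl gives a 2.3-fold lower number from compound 1 to compound 4 (0.36 log units; beyond the scatter). With naphthalen-1-yl held on that nitrogen, 3-fluorophenyl in place of 4-chlorophenyl on the saturated chain carbon bound to an oxygen on an aromatic ring gives a 3.2-fold lower number from compound 2 to compound 4 (0.51 log units; beyond the scatter), so naphthalen-1-yl does not by itself set the higher number seen earlier. Nothing available gives a reason for these steps.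

The compounds shown leave open how a cyclohexyl group or a pyridine ring on the amide-type nitrogen would read in this assay. They also leave open whether the exchange of 4-chlorophenyl for 3-fluorophenyl gives a similar step with other groups on that nitrogen.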